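Adding a chloro group to compound 3

The compounds below may be only part of what the source reports. "The series", "measured", "known", "first", "only" and "open" are said of these compounds alone.

compound 1 `COc1ccc(/C=C/c2cc(OC)c(OC)c(OC)c2-c2ccc(Cl)cc2)cc1` gives 15000 nM
compound 2 `COc1cc(/C=C/c2ccc(C)cc2)c(-c2ccccc2)c(OC)c1OC` gives 31000 nM
compound 3 `C=C(c1ccc(OC)cc1)c1cc(OC)c(OC)c(OC)c1-c1ccccc1` gives 31000 nM

In a functional assay on SK-N-SH cells (Homo sapiens) for cytotoxicity, read by MTT assay, with a stated time of 48 h (on this read-out lower numbers stand for stronger inhibition and higher numbers for weaker inhibition), compound 3 gives 31000 nM as its result, level with compound 2 at the highest of the three numbers, while compound 1 sits lower, beyond the usual scatter. Compound 4 `C=C(c1ccc(OC)cc1)c1cc(OC)c(OC)c(OC)c1-c1ccc(Cl)cc1` has chloro in place of hydrogen on an aromatic carbon, para to a large group (chloro in place of hydrogen on an aromatic carbon), so phenyl becomes 4-chlorophenyl. Among the measured compounds shown here, no measured pair shows this change alone. Compound 1 also carries 4-chlorophenyl and gives 15000 nM as its number, but it differs from compound 3 elsewhere too, making it only a loose guide. In this assay a small step to a lower number is expected, possibly no larger than the scatter. The expected change is a 1.6-fold lower number from compound 3 to compound 4 (0.19 log units; within the scatter) in this estimate. Compound 4 is estimated at 20000 nM with values from 9000 nM to 40000 nM expected.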

Compound 4, half-maximal inhibitory concentration: 15000 nM
For compound 4 the middle estimate is 1.3-fold (0.12 log units) above the measured one, and the stated range covers the measured number.
By their numbers in this assay, from the lowest: compounds 1 and 4 (each within the scatter of the next); then compounds 2 and 3 (each within the scatter of the next).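

In this assay, among the compounds shown here, the change from phenyl to 4-chlorophenyl gives a 2.1-fold lower number from compound 3 to compound 4 (0.32 log units; beyond the scatter) as the first reading of this change on its own. The step is modest, yet it shows that this single change can lower the number on this core. Nothing shown here accounts for the shift.

On these data alone, what fluoro or an amine at the same place would give stays open. So does whether chloro would give a similar step on a different core.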